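Swapping the urea end for a methyl carbamate

The compounds below may be only part of what the source reports. "The series", "measured", "known", "first", "only" and "open" are said of these compounds alone.

Three compounds share one core and differ only at the tail that ends the chain. In a physicochemical assay for permeability, using PAMPA, at pH 7.4 (on this read-out higher numbers stand for higher permeability and lower numbers for lower permeability), compound 1 `CC(C)(C)OC(=O)NCCS(=O)(=O)NC(=O)c1ccc(Nc2nc(NC3(c4ccc(Cl)cc4)CC3)nc(OCC(F)(F)F)n2)cc1` gives 111 nm/s, compound 2 `CC(C)OC(=O)NCCS(=O)(=O)NC(=O)c1ccc(Nc2nc(NC3(c4ccc(Cl)cc4)CC3)nc(OCC(F)(F)F)n2)cc1` gives 71 nm/s, and compound 3 `CNC(=O)NCCS(=O)(=O)NC(=O)c1ccc(Nc2nc(NC3(c4ccc(Cl)cc4)CC3)nc(OCC(F)(F)F)n2)cc1` gives 40 nm/s. Compound 3 holds the lowest of the three numbers: there was a 2.8-fold lower number from compound 1 to compound 3 (0.44 log units; beyond the scatter), while there was a 1.8-fold lower number from compound 2 to compound 3 (0.25 log units; within the scatter), and the first two compounds differ by a 1.6-fold lower number from compound 1 to compound 2 (0.19 log units; within the scatter).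

Compound 4 `COC(=O)NCCS(=O)(=O)NC(=O)c1ccc(Nc2nc(NC3(c4ccc(Cl)cc4)CC3)nc(OCC(F)(F)F)n2)cc1` is reached from compound 3 by methoxy in place of methylamino on a carbonyl carbon. The measured steps that bear on this run the other way, from an alkoxy group to methylamino, and both moved the number down, the larger one beyond the scatter. Going back from methylamino to an alkoxy group should therefore lift the number, though the entering group is smaller than the tert-butoxy or isopropoxy groups seen so far, so the lift is expected to be small. The expected step is a 1.4-fold higher number from compound 3 to compound 4 (0.14 log units; within the scatter), giving compound 4 an estimated value of 55 nm/s, ranging from 30 nm/s to 100 nm/s in this assay.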

Compound 4, apparent permeability: 39 nm/s
Compound 4: the middle estimate sits 1.4-fold (0.15 log units) above what was measured; the range from low to high includes it.
By their numbers in this assay, from the lowest: compounds 4, 3, 2 and 1 (each within the scatter of the next, the first and the last beyond it).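

In this assay the change shows a 1.0-fold lower number from compound 3 to compound 4 (0.01 log units; within the scatter) and so leaves the two ends level, even though methylamino carries a hydrogen-bond donor and methoxy does not. Among the alkoxy groups on this carbonyl carbon, the data show a 1.8-fold lower number from compound 2 to compound 4 (0.26 log units; within the scatter) but also a 2.8-fold lower number from compound 1 to compound 4 (0.45 log units; beyond the scatter) and thus separate only the tert-butyl end from the methyl end, with the isopropyl end not distinct from either neighbour. Nothing measured here accounts for these steps.

Still open, on these data alone, is how a longer straight chain on the oxygen, such as butoxy, or a ring such as cyclopropoxy would compare with these tails. As far as these compounds go, it is also open what would happen if the carbonyl group were replaced altogether, leaving a free amine or a carboxylic acid at the end of the chain.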